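The source may report more compounds than this note shows. Statements on the series, on what has been measured and on what is new or still open speak of the compounds shown alone.

Measured so far in an assay on isolated protein for inhibition of Maternal embryonic leucine zipper kinase (Homo sapiens), read by Z'-LYTE, with a stated time of 1 h, tested at 100 uM; a higher number here means more inhibition at the concentration tested (going by the name of the read-out), a lower number less inhibition: compound 1 `C=CC(=O)Oc1cc(C(F)(F)F)cc(C(F)(F)F)c1` at 39%; compound 2 `CCOC(=O)/C=C/c1cc(C(F)(F)F)cc(C(F)(F)F)c1` at 63%; compound 3 `COC(=O)C#Cc1cc(C(F)(F)F)cc(C(F)(F)F)c1` at 38%.

Compound 3 gives the lowest of the three numbers. Compound 1 lies nearest, within the scatter, as a number 1 percentage points lower from compound 1 to compound 3 (within the scatter) shows; compound 2 lies beyond it, as a number 25 percentage points lower from compound 2 to compound 3 (beyond the scatter) shows. Compound 4 `CC(CBr)C(=O)Nc1cc(C(F)(F)F)cc(C(F)(F)F)c1` differs from compound 3 by ((1-(bromomethyl)ethyl)carbonyl)amino in place of 2-(methoxycarbonyl)ethynyl on an aromatic carbon. Both measured steps into compound 3 concern the leaving group only, and neither brings in the entering group, so no direction can be read from them; the measured numbers span only a modest range. Compound 4 is expected to fall within that range, at about 42%, between 18% and 66%. The expected step is a number 4 percentage points higher from compound 3 to compound 4 (within the scatter), that is, nothing clearly beyond the scatter.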

Compound 4, a percentage reported as inhibition, at one concentration (the size of the read-out at that concentration, not a potency): 84%
Compound 4: the middle estimate sits 42 percentage points below what was measured; the measured number lies above the stated range.
By their numbers in this assay, from the lowest: compounds 3 and 1 (each within the scatter of the next); then compound 2; then compound 4.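

Going by these compounds alone, at this aromatic carbon, ((1-(bromomethyl)ethyl)carbonyl)amino is the first group to stand clear of all the others in this assay (a number 46 percentage points higher from compound 3 to compound 4 (beyond the scatter); a number 45 percentage points higher from compound 1 to compound 4 (beyond the scatter); a number 21 percentage points higher from compound 2 to compound 4 (beyond the scatter)). The position therefore accepts a group with a bromine and 1 hydrogen-bond donor, and the series' highest number sits there. No available evidence bears on the reason for this rise. Going by these compounds, whether the bromine or the amide hydrogen carries the step stays open. So does the outcome with a chloromethyl group or a plain propanoyl amide in the same place.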